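Removing One Methoxy Group: What the Cells Should Show

The source may report more compounds than this note shows. Statements on the series, on what has been measured and on what is new or still open speak of the compounds shown alone.

Measured so far:
- compound 1, `COc1ccc(-c2cc(/C=C/C(=O)c3ccc(N)cc3)[nH]n2)cc1`, gives -47%
- compound 2, `COc1ccc(-c2cc(/C=C/C(=O)c3ccc(N)cc3)[nH]n2)cc1OC`, gives -22%
- compound 3, `COc1cc(C(=O)/C=C/c2cc(-c3cc(OC)c(OC)c(OC)c3)n[nH]2)cc(OC)c1OC`, gives -15%

All three were tested in a functional assay on MOLT-4 cells (Homo sapiens) for cytotoxicity, read by sulforhodamine B assay, with a stated time of 48 h, tested at 100 uM; on this read-out higher numbers stand for a weaker effect at the one concentration tested and lower numbers for a stronger effect. Compound 1 stands out as the strongest of the three, since its distance to both other compounds lies beyond the usual scatter. Compound 2 and compound 3 are within the scatter of each other, so no order between them can be read from these numbers.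

Compound 1 and compound 2 differ in one place: hydrogen in place of methoxy on an aromatic carbon. This change gave a number 25 percentage points lower from compound 2 to compound 1 (beyond the scatter).

Compound 3 carries a different core; the difference between the core of compound 3 and that of compound 2 is not broken down here.

The unmeasured compound 4, `COc1ccc(-c2cc(/C=C/C(=O)c3cc(OC)c(OC)c(OC)c3)[nH]n2)cc1OC`, is reached from compound 3 by the same kind of change: hydrogen in place of methoxy on an aromatic carbon. The surroundings are not identical, however: in compound 3 the carbon in question is also meta to a methoxy group, which was not the case for compound 2.

Because a number 25 percentage points lower from compound 2 to compound 1 (beyond the scatter) was a modest step beyond the scatter, a step of similar direction is expected here, somewhat widened for the different surroundings, giving an expected a number 23 percentage points lower from compound 3 to compound 4 (beyond the scatter). Compound 4 is therefore estimated at -38%, with a likely range from -58% to -18%.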

Compound 4, a percentage reported as activity, at one concentration (the size of the read-out at that concentration, not a potency): -15%
The estimate for compound 4 lay 23 percentage points below the measured number; measured number outside the range, above it.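

In this assay, putting hydrogen in place of methoxy on an aromatic carbon produced no change at the digits printed from compound 3 to compound 4 (within the scatter). The same one-place change therefore did not carry over from one core to the other with the same result, and the two steps differ by more than ordinary measurement noise: the same change on two cores in this assay, a number 25 percentage points lower (beyond the scatter) from compound 2 to compound 1 and no change at the digits printed (within the scatter) from compound 3 to compound 4, 25 percentage points apart, beyond the scatter of two such steps

This shows that, in this series, the result of this change on one core is not a safe guide to its result on another, but two steps cannot show which structural difference between the cores is responsible or predict what would happen on a third core.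

The compounds shown leave open how other groups in place of the methoxy group, such as a hydroxyl group, a fluorine atom or an ethoxy group, would behave at this carbon on either core. They also leave open whether the two steps would keep this contrast at other concentrations, as each number in this assay gives the size of the read-out at one concentration and is not a potency.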